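Replacing the ethylsulfonylpyridine group in compound 1

The source may hold more compounds than are shown below. What is called first, only, known or untested is meant among the compounds shown, and "the series" means these compounds.

Values measured so far in a physicochemical assay for lipophilicity, at pH 7.4; a lower number here means a more polar compound, a higher number a more lipophilic compound
- compound 1 `CCS(=O)(=O)c1ccc(CN(CC(C)C)S(=O)(=O)c2ccc3c(c2)C(O)CC(C2CCOCC2)O3)nc1` gives 1.42
- compound 2 `CCc1ccc(N(CC(C)C)S(=O)(=O)c2ccc3c(c2)C(O)CC(CC2CCOCC2)O3)cc1` gives 4.44

Compound 1 stands at the lower of the two numbers, and the gap up to compound 2 lies beyond the usual scatter. The two compounds differ in more than one place, so their gap does not isolate any single change.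

The next compound to be measured is compound 3 `CC(C)CN(Cc1ccccc1C(F)(F)F)S(=O)(=O)c1ccc2c(c1)C(O)CC(C1CCOCC1)O2`. Its difference from compound 1 is 2-(trifluoromethyl)phenyl in place of 5-(ethylsulfonyl)pyridin-2-yl on a saturated chain carbon bound to a sulfonamide nitrogen, with 2-(trifluoromethyl)phenyl in place of 5-(ethylsulfonyl)pyridin-2-yl on a saturated chain carbon bound to a sulfonamide nitrogen. The core of compound 1 is kept.

Among the measured compounds shown here, no measured pair shows this change on its own, so the expectation rests on the counts of what leaves and what enters, with compound 2 at 4.44 as the only higher reference. A rise beyond the scatter is expected, and the estimated size is a number 2.08 log units higher from compound 1 to compound 3 (beyond the scatter) in this assay. The estimate for compound 3 is 3.5, with an expected range of 2.9 to 4.1.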

Compound 3, distribution coefficient: 4.23
Estimate against measurement, compound 3: 0.73 log units below, outside the stated range (above it).
By their numbers in this assay, from the lowest: compound 1; then compounds 3 and 2 (each within the scatter of the next).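

In this assay, among the compounds shown here, 2-(trifluoromethyl)phenyl in place of 5-(ethylsulfonyl)pyridin-2-yl on a saturated chain carbon bound to a sulfonamide nitrogen gives a number 2.81 log units higher from compound 1 to compound 3 (beyond the scatter) with the core of compound 1 kept, so this is the first step that can be read at a single place. The read-out therefore depends strongly on the group at this position, which the earlier pair could not show because its members differ in more than one place. The size of the exchange hardly changes, while hydrogen-bond acceptors go from 3 to 0, but no measurement available here links the step to any one feature of either group.

For the compounds shown here, the single step changes the ring nitrogen, the ethylsulfonyl group and the trifluoromethyl group together, so the share of each stays open. The compounds shown also leave open where a nitrile, a carboxylic acid or an amine on the same aromatic ring would fall on this scale.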